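Side-chain ring swap from compound 1 to compound 4

The source may report more compounds than this note shows. Statements on the series, on what has been measured and on what is new or still open speak of the compounds shown alone.

Compound 1 `Nc1ncnc2c1c(Oc1cccc(Cl)c1)nn2CC1CCOCC1` gives 0.233 h in an ADME assay on microsomes from liver (Rattus norvegicus) for metabolic stability, read by LC-MS, tested at 1 uM (on this read-out higher numbers stand for a longer-lived compound and lower numbers for a shorter-lived compound), the lowest of the three numbers shown, though both others lie within the scatter of it: compound 3 `Nc1ncnc2c1c(Nc1cccc(Cl)c1)nn2CC1CCNCC1` gives 0.333 h and compound 2 `Cc1cccc(Sc2nn(CC3CCNCC3)c3ncnc(N)c23)c1` gives 0.433 h in this assay. Among the compounds with values here, the one single-point step among measured compounds, a 1.3-fold lower number from compound 2 to compound 3 (0.11 log units; within the scatter), concerns the group on the aromatic carbon, not the side chain. Compound 4 `Nc1ncnc2c1c(Oc1cccc(Cl)c1)nn2CC1CCCNC1` differs from compound 1 by piperidin-3-yl in place of oxan-4-yl on a saturated chain carbon bound to an aromatic nitrogen. Within the data shown here, no measured step swaps these two rings, and all three measured numbers fall in one band. A step of a 1.3-fold higher number from compound 1 to compound 4 (0.11 log units; within the scatter) is therefore expected, nothing beyond the scatter. Compound 4 is estimated at 0.3 h, with a range of 0.15 h to 0.6 h.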

Compound 4, half-life: > 1 h
Compound 4 ended at the assay's limit (the forecaster's own chance of this, stated with the estimate: 5%); middle value at least 3.3-fold (0.52 log units) from the limit.
By their numbers in this assay, from the lowest: compounds 1, 3 and 2 (each within the scatter of the next). At a limit, above all of these: compound 4.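

The place on a saturated chain carbon bound to an aromatic nitrogen is sensitive in this assay: piperidin-3-yl in place of oxan-4-yl gives an at least 4.2-fold higher number from compound 1 to compound 4 (0.63 log units; beyond the scatter). Within the data shown here, the only earlier step concerned the group on an aromatic carbon and stayed within the scatter. Compound 4 stands at a limit of the assay and not at a number, and the full size of the step stays unknown: the limit of > 1 h in this assay, at which 1 of the 4 values shown sits.

The compounds shown do not separate the ring nitrogen from its place in the ring. A pyrrolidin-3-yl ring, or an acetyl group on the ring nitrogen, would test how far this result holds.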